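Clearance notes: adamantane peroxide series, amine-bearing aryl ether tails

This account rests on a few compounds, and the source may have more. Where it says the series, first, only, none or still open, it means among the compounds named here.

Measured so far:
compound 1 `N[C@H]1CC[C@@H](Oc2ccc([C@H]3CC[C@]4(CC3)OOC3(O4)C4CC5CC(C4)CC3C5)cc2)CC1`: < 7 mL.min-1.g-1 in an ADME assay on microsomes from liver (Homo sapiens) for metabolic stability, read by LC-MS, tested at 1 uM; a lower number here means slower removal, a higher number faster removal of the compound (a limit of the assay, not a number)
compound 2 `CC(C)(O)CNCCCOc1ccc([C@H]2CC[C@]3(CC2)OOC2(O3)C3CC4CC(C3)CC2C4)cc1`: 8 mL.min-1.g-1

For the measured compounds named here, compound 2 holds the only numerical value in this assay; the other entry is a limit. In this assay compound 1 gives < 7 mL.min-1.g-1, which is a limit. Going by the values given here, the single measured step, an at least 1.1-fold higher number from compound 1 to compound 2 (0.05 log units; that floor lies within the scatter), came with a change of 3-((2-hydroxy-2-methylpropyl)amino)propyl in place of 4-aminocyclohexyl on an oxygen on an aromatic ring; it lies within the scatter, and it rests on (the limit of < 7 mL.min-1.g-1 in this assay, at which 1 of the 2 values shown sits).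

Compound 3 `NCCCCOc1ccc([C@H]2CC[C@]3(CC2)OOC2(O3)C3CC4CC(C3)CC2C4)cc1` is the next member. Its difference from compound 2 is aminomethyl in place of (2-hydroxy-2-methylpropyl)amino on a saturated chain carbon, three bonds along the chain from an oxygen on an aromatic ring. Among the compounds with values here, that change is not covered by the one measured step, which alters a different part of the chain and was itself within the scatter. No basis exists here for expecting a step beyond the scatter. Compound 3 is therefore expected to sit near compound 2, with an estimated step of a 1.1-fold lower number from compound 2 to compound 3 (0.06 log units; within the scatter). For compound 3 the estimate in this assay is 7 mL.min-1.g-1, with a range from 3.5 mL.min-1.g-1 to 14 mL.min-1.g-1.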

Compound 3, intrinsic clearance in microsomes: < 7 mL.min-1.g-1
Compound 3 gave a limit, no number; the forecaster's own chance of this, stated with the estimate: 45%; the middle value lies on the limit itself.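

In this assay, for the compounds shown here, aminomethyl in place of (2-hydroxy-2-methylpropyl)amino, on a saturated chain carbon, three bonds along the chain from an oxygen on an aromatic ring, gives an at least 1.1-fold lower number from compound 2 to compound 3 (0.05 log units; that floor lies within the scatter), so this change at this place shows no step that can be told from the scatter, and its full size stays unknown. Compound 3 gives < 7 mL.min-1.g-1, which is a limit of the assay and not a number. The step from compound 1 to compound 3, 4-aminobutyl in place of 4-aminocyclohexyl on an oxygen on an aromatic ring, cannot be read, and the open chain and the ring-bearing tail can only be said to share one limit, with both ends of that step being limits: the limit of < 7 mL.min-1.g-1 in this assay, at which 2 of the 3 values shown sit.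

The compounds shown leave open how the read-out in this assay responds to a longer chain than 4-aminobutyl, to a carboxylic acid in place of the amine at the chain end, or to a dimethylamino end group. Also open, on these data alone, is whether any tail at this limit differs from another, since only compound 2 carries a number.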